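The source may report more compounds than this note shows. Statements on the series, on what has been measured and on what is new or still open speak of the compounds shown alone.

Among the compounds with values here, in a functional assay on the whole organism for antagonist activity, with Mus musculus as the target (a higher number here means that more compound is needed for the effect, a lower number that less compound is needed), compound 1 `CN(C(=O)CNC(=O)CN1CCCCC1)c1ccc(Cl)cc1C(=O)c1ccccc1Cl` gives 7.5 mg/kg as the highest of the three numbers measured so far. Lower numbers belong to compound 2 `CC(C)NCC(=O)NCC(=O)N(C)c1ccc(Cl)cc1C(=O)c1ccccc1Cl` (1 mg/kg) and compound 3 `CC(=O)NCC(=O)N(C)c1ccc(Cl)cc1C(=O)c1ccccc1Cl` (2.3 mg/kg). Compound 4 `CN(C(=O)CNC(=O)c1ccccc1)c1ccc(Cl)cc1C(=O)c1ccccc1Cl` is not yet measured and differs from compound 1 in one place (phenyl in place of (piperidin-1-yl)methyl on a carbonyl carbon). Two measured steps also remove piperidin-1-yl, one with isopropylamino in its place (a 7.5-fold lower number from compound 1 to compound 2 (0.88 log units; beyond the scatter)) and one with hydrogen in its place (a 3.3-fold lower number from compound 1 to compound 3 (0.51 log units; beyond the scatter)), and both are modest. The two outcomes also differ from each other (a 2.3-fold higher number from compound 2 to compound 3 (0.36 log units; beyond the scatter)). Neither replacement is phenyl, so they guide only loosely. In this assay a modest step to a lower number is therefore expected (a 3.0-fold lower number from compound 1 to compound 4 (0.48 log units; beyond the scatter)). Compound 4 is estimated at 2.5 mg/kg (expected range 0.8 mg/kg to 7.5 mg/kg).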

Compound 4, dose for half-maximal effect: 2.9 mg/kg
For compound 4 the middle estimate is 1.2-fold (0.06 log units) below the measured one; low and high end bracket the measured number.
By their numbers in this assay, from the lowest: compound 2; then compounds 3 and 4 (each within the scatter of the next); then compound 1.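

At the carbonyl carbon, a six-membered ring does not by itself keep the number high in this assay: phenyl in place of (piperidin-1-yl)methyl still lowers it (a 2.6-fold lower number from compound 1 to compound 4 (0.41 log units; beyond the scatter)). Phenyl and methyl cannot be told apart here (a 1.3-fold higher number from compound 3 to compound 4 (0.10 log units; within the scatter)), while (isopropylamino)methyl stands apart from phenyl (a 2.9-fold higher number from compound 2 to compound 4 (0.46 log units; beyond the scatter)). Nothing available explains these differences. The compounds shown leave open whether a smaller amine, such as aminomethyl, would match the isopropylamino compound. They also leave open how a carboxylic acid or a longer chain at this carbon would compare.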